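Extending a Piperazine Substituent: Expected Tolerated Concentration

A few compounds are considered here, and "the series" means these few. Any claim that something is new, unique, unknown or untested is made for them only; others in the source may bear on it.

Measured so far:
compound 1 `CC1(C)[C@H]2CC[C@]1(C)[C@H](OC(=O)CN1CCCCC1)C2` gives 141000 nM
compound 2 `CN1CCN(CC(=O)O[C@@H]2C[C@@H]3CC[C@@]2(C)C3(C)C)CC1` gives 313000 nM

Going by the values given here, in an ADME assay on HEK-293T cells (Homo sapiens) for cytotoxicity, read by MTT assay, with a stated time of 48 h (a lower number here means that less compound is tolerated, a higher number that more compound is tolerated), compound 2 stands with the higher of the two numbers; the only comparison available is a 2.2-fold higher number from compound 1 to compound 2 (0.35 log units; beyond the scatter). Compound 3 `CC1(C)[C@H]2CC[C@]1(C)[C@H](OC(=O)CN1CCN(CCN)CC1)C2` differs from compound 2 by aminomethyl in place of hydrogen on a saturated chain carbon bound to an amine nitrogen in a ring. Among the compounds with values here, no measured step adds a group of this kind; the single known step swapped one ring for another and was modest. The expected step for compound 3 is therefore a 1.1-fold higher number from compound 2 to compound 3 (0.05 log units; within the scatter), lying within the scatter. Compound 3 is estimated to give 350000 nM, with a range from 150000 nM to 800000 nM.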

Compound 3, half-maximal cytotoxic concentration: 247000 nM
Compound 3: the middle estimate sits 1.4-fold (0.15 log units) above what was measured, within the range that was stated.
By their numbers in this assay, from the lowest: compounds 1, 3 and 2 (each within the scatter of the next, the first and the last beyond it).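

In this assay the change from methyl to 2-aminoethyl gives a 1.3-fold lower number from compound 2 to compound 3 (0.10 log units; within the scatter) and so leaves compound 3 indistinguishable from compound 2. The earlier step only exchanged one ring group for another, whereas this one shows that a chain ending in an amine can be added at this position with no shift that stands clear of the scatter. No available evidence bears on this result. The compounds shown leave open how a longer chain, or a carboxylic acid in place of the terminal amine, would read here.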